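A few compounds are considered here, and "the series" means these few. Any claim that something is new, unique, unknown or untested is made for them only; others in the source may bear on it.

Measured compounds:
compound 1, `CCc1cccc(NC(=O)CN2CCN(c3ccccn3)CC2)c1`, gives 26.2% in an assay on cells for agonist activity at D(4) dopamine receptor (Homo sapiens), read by luminescence and beta-arrestin recruitment, with a stated time of 90 min; a lower number here means a smaller maximal response, a higher number a larger maximal response
compound 2, `Cc1cccc(NC(=O)CN2CCN(c3ccc(Cl)cn3)CC2)c1`, gives "not active" (no number reported) in this assay
compound 3, `Cc1ccc(C2CCN(CC(=O)Nc3cccc(C)c3)CC2)cc1`, gives "not active" (no number reported) in this assay

Compound 2 stands with no single number in this assay: it was recorded as inactive, and compound 3 shares that status. Going by the values given here, only compound 1 gives a measured maximal response, 26.2%, and compound 1 differs from compound 2 in more than one place, so no single step between them can be counted.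

Compound 4, `CCc1cccc(NC(=O)CN2CCN(c3ccc(Cl)cn3)CC2)c1`, has not yet been measured. Compared with compound 2, the change is methyl in place of hydrogen on a saturated chain carbon bound to an aromatic carbon. Among the compounds with values here, this is a small change in the count of atoms, and no step between measured compounds is available to show its size. With compound 2 reported inactive, the expectation for compound 4 is that the step in this assay stays small, in either direction or not beyond the scatter, with a real chance that compound 4 also comes back without a number. Compound 4 is estimated at 15%, in a range from 0% to 35%.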

Compound 4, largest response reached (Emax), in percent of the reference or control that the assay uses: "not active" (no number reported)
No number was reported for compound 4, so the estimate cannot be set against anything.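

Going by these compounds alone, compound 2 and compound 4 are both recorded as not active in this assay, and no step between them can be read. The compounds shown leave open whether going from 3-methylphenyl to 3-ethylphenyl changes the maximal response where one can be measured. No measured evidence bears on this result.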